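Swapping a ketone chain for a sulfur ring on the core

This account rests on a few compounds, and the source may have more. Where it says the series, first, only, none or still open, it means among the compounds named here.

Of the compounds shown here, three built on a shared core have been tested in a functional assay on DA-3 cells for cytotoxicity against DA-3 cell line (Mus musculus), read by MTT assay; a lower number here means a stronger inhibitor, a higher number a weaker inhibitor. Compound 1 `CC(=O)O[C@@H]1OC(=O)[C@](C)(C(C)=O)[C@@H]1C` gives 7000 nM, compound 2 `CC(=O)O[C@@H]1OC(=O)[C@](Cc2ccccc2)(C(C)=O)[C@@H]1C` gives 45000 nM, and compound 3 `CC(=O)CC[C@]1(C(C)=O)C(=O)O[C@@H](OC(C)=O)[C@H]1C` gives 8000 nM. Compound 3 therefore stands second highest of the three numbers, close to compound 1 and well apart from compound 2. The steps between them are a 1.1-fold higher number from compound 1 to compound 3 (0.06 log units; within the scatter), a 6.4-fold higher number from compound 1 to compound 2 (0.81 log units; beyond the scatter) and a 5.6-fold lower number from compound 2 to compound 3 (0.75 log units; beyond the scatter).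

Compound 4 `CC(=O)O[C@@H]1OC(=O)[C@@](C(C)=O)(C2SCCCS2)[C@@H]1C` differs from compound 3 in one place: a group of 6 heavy atoms (4 carbon, 2 sulfur; one six-membered non-aromatic ring with 2 hetero atoms) in place of a group of 5 heavy atoms (4 carbon, 1 oxygen; no ring), on a saturated ring carbon. Two of the measured steps bear on this change, since each compares a ring-bearing group with a chain or a hydrogen at the same saturated ring carbon. Both go the same way: the ring-bearing compound 2 sits modestly higher than compound 1 and compound 3, while the chain-bearing compound 3 sits within the scatter of compound 1. A modest rise is therefore expected from compound 3 to compound 4, though the entering ring is not aromatic and the guide is thin. Compound 4 is expected to give 20000 nM in this assay, with a range from 7000 nM to 60000 nM. The estimated step is a 2.5-fold higher number from compound 3 to compound 4 (0.40 log units; beyond the scatter).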

Compound 4, half-maximal inhibitory concentration: > 50000 nM
Compound 4: no number, only a limit; the forecaster's own chance of this, stated with the estimate: 10%; middle value at least 2.5-fold (0.39 log units) away from the limit.
By their numbers in this assay, from the lowest: compounds 1 and 3 (each within the scatter of the next); then compound 2. At a limit, above all of these: compound 4.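

In this assay compound 4 gives no number, only a limit: the limit of > 50000 nM in this assay, at which 1 of the 4 values shown sits. The six-membered ring with its two sulfur atoms, set on this saturated ring carbon, clearly raises the number over both the 2-acetylethyl chain, an at least 6.2-fold higher number from compound 3 to compound 4 (0.79 log units; beyond the scatter), and the single carbon of the shared core, an at least 7.1-fold higher number from compound 1 to compound 4 (0.85 log units; beyond the scatter). Until now only the aromatic ring had given such a rise; a non-aromatic ring gives one too, and the two rings stay unseparated, with an at least 1.1-fold higher number from compound 2 to compound 4 (0.04 log units; that floor lies within the scatter).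

From the compounds shown here alone, how far compound 4 lies past its limit stays unknown, so its true distance from compound 2 remains open. Going by these compounds, whether the rise follows the ring itself or its sulfur atoms is also open, and an open-chain thioether, an amine or a carboxylic acid on this carbon would bear on that.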